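This account rests on a few compounds, and the source may have more. Where it says the series, first, only, none or still open, it means among the compounds named here.

Among the compounds with values here, in a functional assay on SH-SY5Y cells (Homo sapiens) for cytotoxicity, read by MTT assay, with a stated time of 72 h (a lower number here means a stronger inhibitor, a higher number a weaker inhibitor), compound 3 `CC1(C)OC[C@H](Cn2cc(Cn3c4c(c5ccccc53)C(=O)c3c[n+]([O-])c5ccccc5c3C4=O)nn2)O1` gives 820 nM, the highest of the three numbers so far. Compound 2 `CC1(C)OCC(Cn2cc(Cn3c4c(c5ccccc53)C(=O)c3c[n+]([O-])c5ccccc5c3C4=O)nn2)O1` gives 230 nM and compound 1 `O=C1c2c[n+]([O-])c3ccccc3c2C(=O)c2c1c1ccccc1n2Cc1cn([C@@H]2C[C@H](O)[C@@H](CO)O2)nn1` gives 150 nM. The change to compound 4 `O=C1c2c[n+]([O-])c3ccccc3c2C(=O)c2c1c1ccccc1n2Cc1cn([C@H]2C[C@H](O)[C@@H](CO)O2)nn1` is 4-hydroxy-5-(hydroxymethyl)oxolan-2-yl in place of (2,2-dimethyl-1,3-dioxolan-4-yl)methyl on an aromatic nitrogen. Compound 1 carries a group of the same name, so the opposite exchange bears on this change. It gave a 5.5-fold higher number from compound 1 to compound 3 (0.74 log units; beyond the scatter), but also a 1.5-fold higher number from compound 1 to compound 2 (0.19 log units; within the scatter). The remaining measured step, a 3.6-fold higher number from compound 2 to compound 3 (0.55 log units; beyond the scatter), goes with the fact that one of compounds 2 and 3 is drawn with a defined configuration and the other without, at the place where they differ. The size of the exchange therefore depends on which dioxolane compound serves as reference. A lower number is expected, somewhat short of the full reversal of the larger step, with an estimated 3.3-fold lower number from compound 3 to compound 4 (0.52 log units; beyond the scatter). Compound 4 is estimated at 250 nM, with an expected range of 90 nM to 700 nM.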

Compound 4, half-maximal inhibitory concentration: 620 nM
Compound 4: middle estimate off by 2.5-fold (0.39 log units), on the low side, within the range that was stated.
By their numbers in this assay, from the lowest: compounds 1 and 2 (each within the scatter of the next); then compounds 4 and 3 (each within the scatter of the next).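

Read in this assay the exchange to 4-hydroxy-5-(hydroxymethyl)oxolan-2-yl on this aromatic nitrogen gives a 1.3-fold lower number from compound 3 to compound 4 (0.12 log units; within the scatter) but a 2.7-fold higher number from compound 2 to compound 4 (0.43 log units; beyond the scatter) so its reading depends on the dioxolane reference. The entering group alone therefore does not fix the number at this position. With the oxolane group kept, there is a 4.1-fold higher number from compound 1 to compound 4 (0.62 log units; beyond the scatter) and this step goes with one difference: the fact that compounds 1 and 4 differ only in the configuration as drawn.

The compounds shown leave open how an amine or a carboxylic acid on this nitrogen would compare. Also open, on these data alone, is how the dioxolane drawn with the opposite configuration would compare with compound 3.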